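Dropping One Fluoro: Expected Effect on Microsomal Clearance

This account rests on a few compounds, and the source may have more. Where it says the series, first, only, none or still open, it means among the compounds named here.

Two compounds that share a common core have been run in an ADME assay on microsomes from liver (Mus musculus) for metabolic stability, read by LC-MS, using NADPH; on this read-out lower numbers stand for slow clearance and higher numbers for fast clearance. Compound 1 `CCC(C)(C)C(=O)N(O)Cc1cc(F)cc(F)c1F` gives 75.3 uL/min, and compound 2 `CCC(C)(C)C(=O)N(O)Cc1ccc(F)c(F)c1F` gives 49.9 uL/min. On these numbers compound 2 stands with the lowest of the two values, its nearest neighbour being compound 1 at a number that lies within the scatter, so no order between the two can be claimed. Compound 3 `CCC(C)(C)C(=O)N(O)Cc1ccc(F)cc1F` has not yet been measured in this assay. It differs from compound 2 by hydrogen in place of fluoro on an aromatic carbon. Among the measured compounds shown here, no step between measured compounds that differ in one place is available, and the two values that exist lie within the scatter of each other, so the data give no guide to the size or direction of such a change. Given that compound 2 gives 49.9 uL/min, compound 3 is expected to show a step of a 1.2-fold higher number from compound 2 to compound 3 (0.08 log units; within the scatter), which amounts to nothing beyond the scatter. The estimate for compound 3 in this assay is 60 uL/min, with a range from 30 uL/min to 120 uL/min.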

Compound 3, intrinsic clearance in a liver preparation (reported as CLH), per the amount of preparation that the assay uses: 29.9 uL/min
The estimate for compound 3 lay 2.0-fold (0.30 log units) above the measured number; the whole stated range lies above it.
By their numbers in this assay, from the lowest: compounds 3, 2 and 1 (each within the scatter of the next, the first and the last beyond it).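

In this assay, among the compounds shown here, the exchange of fluoro for hydrogen on this aromatic carbon, which is ortho to two fluoro groups and meta to a large group, gives a 1.7-fold lower number from compound 2 to compound 3 (0.22 log units; within the scatter), the first step in this set between compounds that differ in one place. It shows that at this position, hydrogen can take the place of fluoro without a difference that stands clear of the usual scatter of the read-out, so this fluoro is not shown to matter for clearance in this preparation. Nothing measured here offers an explanation for the step.

Going by these compounds, whether a chlorine atom, a methoxy group or an amine on this same aromatic carbon would give a step beyond the scatter remains open. Also open, on these data alone, is whether hydrogen in place of either of the two remaining fluoro groups would give such a step, and whether the step seen here would hold with a longer chain in place of the acyl group of the shared core.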